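Oxalamide acids at the free fatty acid receptor: a methoxyphenyl analogue

The compounds below may be only part of what the source reports. "The series", "measured", "known", "first", "only" and "open" are said of these compounds alone.

Measured so far:
compound 1, `O=C(O)COc1ccc(NC(=O)C(=O)Nc2ccccc2)cc1F`, 26.5%
compound 2, `Cc1ccc(NC(=O)C(=O)Nc2ccc(OCC(=O)O)c(F)c2)cc1`, 29.9%

In a functional assay on CHO cells for agonist activity at Free fatty acid receptor 1 (Homo sapiens), read by FLIPR, tested at 300 nM (on this read-out lower numbers stand for a weaker effect and higher numbers for a stronger effect at the one concentration tested), compound 1 gives 26.5% and compound 2 gives 29.9%. Compound 2 holds the higher of the two numbers, but the step of a number 3.4 percentage points higher from compound 1 to compound 2 (within the scatter) lies within the scatter, so the two compounds cannot be told apart on this read-out. Compound 3, `COc1ccccc1NC(=O)C(=O)Nc1ccc(OCC(=O)O)c(F)c1`, has not yet been measured. It differs from compound 2 by 2-methoxyphenyl in place of 4-methylphenyl on an amide-type nitrogen. Going by the values given here, the only measured step, a number 3.4 percentage points higher from compound 1 to compound 2 (within the scatter), concerns a different change and offers no guide to what a methoxy group on the entering 2-methoxyphenyl does; no compound with such a group has been measured here. With nothing to point either way, the step of a number 1.9 percentage points lower from compound 2 to compound 3 (within the scatter) is expected to stay within the scatter. Compound 3 is therefore estimated at 28%, with a range from 14% to 42%.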

Compound 3, a percentage reported as activity, at one concentration (the size of the read-out at that concentration, not a potency): 19.9%
Compound 3: middle estimate off by 8.1 percentage points, on the high side; measured number inside the range.
By their numbers in this assay, from the lowest: compounds 3, 1 and 2 (each within the scatter of the next).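

In this assay, 2-methoxyphenyl in place of 4-methylphenyl on the amide-type nitrogen gives a number 10 percentage points lower from compound 2 to compound 3 (within the scatter) and adding a methoxy group gives a number 6.6 percentage points lower from compound 1 to compound 3 (within the scatter) so neither change can be told from repeat scatter. This is the first oxygen-bearing group tested on this ring, and the three compounds shown remain indistinguishable from their nearest neighbours, so this position accepts a methyl or a methoxy group with no step beyond the scatter. Nothing available here explains these readings.

From the compounds shown here alone, it remains open whether an amine or a carboxylic acid on this ring, or a longer chain in place of methoxy, would produce a clear step. Going by these compounds, whether any such group could raise the reading well beyond these three compounds is also open.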